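This account rests on a few compounds, and the source may have more. Where it says the series, first, only, none or still open, it means among the compounds named here.

Compound 3 `C/C=C/C(NC(=O)c1ccc(C(=N)N)cc1)C(C)(C)C(=O)N1CCC(CC(=O)O)CC1` gives 0.933 h in an in vivo ADME assay on the whole organism (Cavia porcellus) (on this read-out higher numbers stand for a longer-lived compound and lower numbers for a shorter-lived compound), the highest of the three numbers measured, though every gap to the others is within the scatter. Compound 1 `CC(NC(=O)c1ccc(C(=N)N)cc1)C(C)(C)C(=O)N1CCC(CC(=O)O)CC1` gives 0.883 h in this assay, and compound 2 `CC(C)C(NC(=O)c1ccc(C(=N)N)cc1)C(C)(C)C(=O)N1CCC(CC(=O)O)CC1` gives 0.8 h. The three steps among them, a 1.1-fold lower number from compound 1 to compound 2 (0.04 log units; within the scatter), a 1.1-fold higher number from compound 1 to compound 3 (0.02 log units; within the scatter) and a 1.2-fold higher number from compound 2 to compound 3 (0.07 log units; within the scatter), all change the same place and all stay within the scatter. Compound 4 `CC(C)(C(=O)N1CCC(CC(=O)O)CC1)C(NC(=O)c1ccc(C(=N)N)cc1)c1ccc2ccccc2c1` changes that same place again: naphthalen-2-yl in place of prop-1-en-1-yl on a saturated chain carbon bound to an amide-type nitrogen and a saturated chain carbon. The measured steps bear on it only in that they touch this position; none brings in a ring, so the guidance is loose. He therefore expects no step beyond the scatter, a 1.0-fold lower number from compound 3 to compound 4 (0.02 log units; within the scatter), and estimates compound 4 at 0.9 h in this assay, within 0.45 h to 1.8 h.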

Compound 4, half-life: 0.85 h
Estimate against measurement, compound 4: 1.1-fold (0.02 log units) above; measured number inside the range.
By their numbers in this assay, from the lowest: compounds 2, 4, 1 and 3 (each within the scatter of the next).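

In this assay, naphthalen-2-yl brings the first rings to this position, with 10 heavy atoms against 3 in prop-1-en-1-yl, yet the steps stay small: a 1.1-fold lower number from compound 3 to compound 4 (0.04 log units; within the scatter), a 1.1-fold higher number from compound 2 to compound 4 (0.03 log units; within the scatter) and a 1.0-fold lower number from compound 1 to compound 4 (0.02 log units; within the scatter). On a saturated chain carbon bound to an amide-type nitrogen and a saturated chain carbon, methyl, isopropyl, prop-1-en-1-yl and naphthalen-2-yl thus all lie within the scatter of one another. Nothing available explains this lack of separation. Going by these compounds, whether an amine or a carboxylic acid at this position would also stay within the scatter remains open.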